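Methoxy for Chloro on the Core of Compound 3

This account rests on a few compounds, and the source may have more. Where it says the series, first, only, none or still open, it means among the compounds named here.

Compound 1 `CCn1cc(-c2cccc(Cl)c2)c(=O)c2cc(F)c(N3CCNCC3)cc21` and compound 2 `CCn1cc(-c2cccc(OC)c2)c(=O)c2cc(F)c(N3CCNCC3)cc21` share one core and differ in a single place: methoxy in place of chloro on an aromatic carbon. In a functional assay on HepG2 cells (Homo sapiens) for antiproliferative activity, read by MTT assay, with a stated time of 48 h (on this read-out higher numbers stand for weaker inhibition and lower numbers for stronger inhibition), compound 1 gives 15300 nM, and compound 2 gives 13000 nM; the step between them is a 1.2-fold lower number from compound 1 to compound 2 (0.07 log units; within the scatter). Compound 3 `O=c1c(-c2cccc(Cl)c2)cn(C2CC2)c2cc(N3CCNCC3)c(F)cc12` carries a different core, and the difference from compound 1 is cyclopropyl in place of ethyl on an aromatic nitrogen. In this assay compound 3 gives 860 nM, the lowest of the three numbers, and the step is an 18-fold lower number from compound 1 to compound 3 (1.25 log units; beyond the scatter). Compound 4 `COc1cccc(-c2cn(C3CC3)c3cc(N4CCNCC4)c(F)cc3c2=O)c1` has not yet been measured. It stands to compound 3 exactly as compound 2 stands to compound 1: methoxy in place of chloro on an aromatic carbon. The surroundings of the place match word for word, so this is the same change, set this time on the core of compound 3. Among the compounds with values here, the only guide is the earlier step, which stayed within the scatter. On that basis the step from compound 3 to compound 4 is expected to be a 1.1-fold lower number from compound 3 to compound 4 (0.06 log units; within the scatter) in this assay. Compound 4 is therefore estimated at 750 nM, with a range from 350 nM to 1700 nM expected.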

Compound 4, half-maximal inhibitory concentration: 910 nM
Estimate against measurement, compound 4: 1.2-fold (0.08 log units) below; measured number inside the range.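

In this assay, methoxy in place of chloro gives a 1.1-fold higher number from compound 3 to compound 4 (0.02 log units; within the scatter), so the change stays within the scatter on the core of compound 3, as it did on the core of compound 1: the same change on two cores in this assay, a 1.2-fold lower number (0.07 log units; within the scatter) from compound 1 to compound 2 and a 1.1-fold higher number (0.02 log units; within the scatter) from compound 3 to compound 4, 1.2-fold (0.10 log units) apart, within the scatter of two such steps. The other change also carries over, for cyclopropyl in place of ethyl on the aromatic nitrogen gives a 14-fold lower number from compound 2 to compound 4 (1.15 log units; beyond the scatter) with methoxy on the aromatic ring, much as it did with chloro: the same change on two cores in this assay, an 18-fold lower number (1.25 log units; beyond the scatter) from compound 1 to compound 3 and a 14-fold lower number (1.15 log units; beyond the scatter) from compound 2 to compound 4, 1.2-fold (0.10 log units) apart, within the scatter of two such steps. These four compounds show that the two changes act alike on each other's background in this one assay, but they do not show that this would hold on any further core or in any other assay, and they give no reason for it.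

From the compounds shown here alone, it remains open whether a carboxylic acid or an amine in place of chloro would also leave the number within the scatter. Going by these compounds, it also remains open how a longer chain, such as propyl or butyl, on the aromatic nitrogen would compare with ethyl and cyclopropyl.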